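Swapping naphthalen-1-yl for 2-methylphenyl at the assay limit

The source may report more compounds than this note shows. Statements on the series, on what has been measured and on what is new or still open speak of the compounds shown alone.

The values in an ADME assay on Vero cells (Chlorocebus sabaeus) for inhibition, read by MTT assay, with a stated time of 72 h (a higher number here means a weaker inhibitor, a lower number a stronger inhibitor), are shown here, and each one is a limit of the assay, not a number.

- Compound 1 `O=C(O)CCCCCCC(=O)Nc1ccc(C2=C(c3ccc(O)cc3)C3CC(S(=O)(=O)Oc4ccccc4C(F)(F)F)C2O3)cc1` gives > 100000 nM
- Compound 2 `O=C(O)CCCCCCC(=O)Nc1ccc(C2=C(c3ccc(O)cc3)C3CC(S(=O)(=O)Oc4cccc5ccccc45)C2O3)cc1` gives > 100000 nM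
- Compound 3 `COc1ccccc1OS(=O)(=O)C1CC2OC1C(c1ccc(NC(=O)CCCCCCC(=O)NO)cc1)=C2c1ccc(O)cc1` gives > 100000 nM

Compound 2 stands at > 100000 nM, which is a limit and not a number. Within the data shown here, the wider record is the limit of > 100000 nM in this assay, at which 3 of the 3 values shown sit, so no measured compound offers a true reading to start from.

The unmeasured compound 4 `Cc1ccccc1OS(=O)(=O)C1CC2OC1C(c1ccc(NC(=O)CCCCCCC(=O)O)cc1)=C2c1ccc(O)cc1` differs from compound 2 in one place: 2-methylphenyl in place of naphthalen-1-yl on an oxygen. Put simply, 2-methylphenyl stands in place of naphthalen-1-yl on an oxygen.

Among the measured compounds shown here, the one measured step that bears on this change is a step that the two limits leave unreadable from compound 1 to compound 2, where naphthalen-1-yl replaces 2-(trifluoromethyl)phenyl on that same oxygen. Its size cannot be read, so it gives no evidence that exchanging this group moves the result in either direction.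

In this assay the expected result is therefore a step that the limit leaves unreadable from compound 2 to compound 4, with no step beyond the usual scatter expected and no direction favoured.

For compound 4 the estimate is 120000 nM, expected to fall between 50000 nM and 300000 nM, and the assay will most likely report only a limit again.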

Compound 4, half-maximal inhibitory concentration: > 100000 nM
Compound 4: no number, only a limit; the forecaster's own chance of this, stated with the estimate: 85%; the middle value is on the limit's open side.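

In this assay, among these compounds, compound 4 gives > 100000 nM, a limit of the assay and not a number, and no step from compound 1 or compound 2 to compound 4 can be read. The compounds shown leave open whether any group on that oxygen would give a true reading, with every value at one limit: the limit of > 100000 nM in this assay, at which 4 of the 4 values shown sit.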